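Replacing the aryl on the amino of compound 1 with cyclopentyl

The compounds below may be only part of what the source reports. "The series", "measured", "known", "first", "only" and "open" are said of these compounds alone.

The series shares one core, seen in compound 1 `COc1ccc2c(c1)NC(=O)CN2c1nc(Nc2cccc(C#N)c2)nc2ccccc12`, compound 2 `COc1ccc2c(c1)NC(=O)CN2c1nc(COC(C)=O)nc2ccccc12` and compound 3 `CCOc1nc(N2CC(=O)Nc3cc(OC)ccc32)c2ccccc2n1`. In a functional assay on MDA-MB-231 cells (Homo sapiens) for inhibition, read by sulforhodamine B assay, with a stated time of 48 h (a lower number here means a stronger inhibitor of growth, a higher number a weaker inhibitor of growth), compound 1 gives 97.1 nM, compound 2 gives 8.95 nM and compound 3 gives 15.4 nM. Compound 1 thus stands with the highest number of the three; the steps to the others, an 11-fold lower number from compound 1 to compound 2 (1.04 log units; beyond the scatter) and a 6.3-fold lower number from compound 1 to compound 3 (0.80 log units; beyond the scatter), both lie beyond the scatter, while the pair a 1.7-fold higher number from compound 2 to compound 3 (0.24 log units; within the scatter) does not.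

Compound 4 `COc1ccc2c(c1)NC(=O)CN2c1nc(NC2CCCC2)nc2ccccc12` keeps the amino of compound 1 and changes what sits on it: cyclopentyl in place of 3-cyanophenyl on a nitrogen on an aromatic ring. For the measured compounds named here, no measured step keeps that amino, so the two steps from compound 1 bear on it only loosely: each removed the (3-cyanophenyl)amino altogether and lowered the number. A smaller lowering is therefore expected for compound 4, a 2.8-fold lower number from compound 1 to compound 4 (0.44 log units; beyond the scatter), since the amino remains. Compound 4 is estimated at 35 nM, within 10 nM to 120 nM.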

Compound 4, concentration for 50% growth inhibition: 17.6 nM
Estimate against measurement, compound 4: 2.0-fold (0.30 log units) above; low and high end bracket the measured number.
By their numbers in this assay, from the lowest: compounds 2, 3 and 4 (each within the scatter of the next); then compound 1.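

With the amino kept, changing only what sits on it already gives a 5.5-fold lower number from compound 1 to compound 4 (0.74 log units; beyond the scatter) in this assay, so the high number of compound 1 does not go with the amino as such but with the 3-cyanophenyl on it. Compound 4 also stays within the scatter of the two compounds that lack the amino, with a 1.1-fold higher number from compound 3 to compound 4 (0.06 log units; within the scatter) and a 2.0-fold higher number from compound 2 to compound 4 (0.29 log units; within the scatter), so at this position cyclopentylamino, ethoxy and acetoxymethyl cannot be told apart, and only (3-cyanophenyl)amino stands off from them. Nothing available here explains this difference.

As far as these compounds go, the step exchanges the aromatic ring and the nitrile together, so which of them goes with the higher number stays open. A plain phenyl on the same nitrogen would separate the two, and a cyclohexyl or an open isopropyl chain would show how far the cyclopentyl ring itself matters.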